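Nucleoside series: methyl to methylsulfanyl on the thiophen-2-yl analogue

The source may report more compounds than this note shows. Statements on the series, on what has been measured and on what is new or still open speak of the compounds shown alone.

Measured compounds:
compound 1 `C#Cc1cn([C@@H]2O[C@H](CO)[C@@H](O)[C@H]2O)c2ncnc(C)c12` gives 1110 nM in a functional assay on HL-60 cells (Homo sapiens) for antiproliferative activity, read by XTT assay, with a stated time of 72 h; a higher number here means a weaker inhibitor, a lower number a stronger inhibitor
compound 2 `Cc1ncnc2c1c(-c1cccs1)cn2[C@@H]1O[C@H](CO)[C@@H](O)[C@H]1O` gives 5730 nM in this assay
compound 3 `Cc1ncnc2c1c(-c1ccsc1)cn2[C@@H]1O[C@H](CO)[C@@H](O)[C@H]1O` gives 350 nM in this assay

Compound 2 stands highest of the three numbers, the weakest inhibitor of the set: compound 1 sits at a 5.2-fold higher number from compound 1 to compound 2 (0.71 log units; beyond the scatter) and compound 3 at a 16-fold lower number from compound 2 to compound 3 (1.21 log units; beyond the scatter), both gaps beyond the scatter. The measured steps all concern the substituent on the five-membered ring: a 5.2-fold higher number from compound 1 to compound 2 (0.71 log units; beyond the scatter), a 3.2-fold lower number from compound 1 to compound 3 (0.50 log units; beyond the scatter) and a 16-fold lower number from compound 2 to compound 3 (1.21 log units; beyond the scatter).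

Compound 4 `CSc1ncnc2c1c(-c1cccs1)cn2[C@@H]1O[C@H](CO)[C@@H](O)[C@H]1O` differs from compound 2 in one place: methylsulfanyl in place of methyl on an aromatic carbon. For the measured compounds named here, none of the measured steps touches this position; the methyl is kept in all three measured compounds. Going by the values given here, there is therefore no step in this assay that bears directly on this change, and no direction can be read from the data. Without a bearing step, the expectation for compound 4 is a number close to that of compound 2, with a wide range to either side, the expected step being a 1.3-fold lower number from compound 2 to compound 4 (0.10 log units; within the scatter). Compound 4 is estimated at 4500 nM, between 1000 nM and 20000 nM.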

Compound 4, half-maximal inhibitory concentration: 1130 nM
For compound 4 the middle estimate is 4.0-fold (0.60 log units) above the measured one, within the range that was stated.
By their numbers in this assay, from the lowest: compound 3; then compounds 1 and 4 (each within the scatter of the next); then compound 2.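

In this assay, for the compounds shown here, the methyl-bearing carbon, on the six-membered aromatic ring with 2 nitrogen, proves responsive for the first time: with thiophen-2-yl held constant, methylsulfanyl in place of methyl gives a 5.1-fold lower number from compound 2 to compound 4 (0.71 log units; beyond the scatter) and so a stronger inhibitor. Going by these compounds alone, the earlier compounds all carried the methyl and could speak only to the substituent on the five-membered ring, so this is the first sign that the series can be moved from this second site as well. The available data offer no measured basis for explaining the step.

The step rests on the thiophen-2-yl analogue alone, and the compounds shown leave open whether methylsulfanyl in place of methyl has the same direction or size with thiophen-3-yl or ethynyl on the five-membered ring. They also leave open how this site responds to other groups, such as an amine, a methoxy group or the longer ethylsulfanyl chain, and so whether the sulfur or simply the larger group tracks with the lower number.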